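Swapping Methoxy for Chloro on the Aryl Ring

The source may hold more compounds than are shown below. What is called first, only, known or untested is meant among the compounds shown, and "the series" means these compounds.

Among the measured compounds shown here, compound 2 `COc1ccc(-c2cc(/N=C3\SCC(=O)N3c3cccc(OC)c3)cs2)cc1` is the only compound of this pair with a definite number: in a functional assay on MDA-MB-231 cells (Homo sapiens) for cytotoxicity, read by MTT assay, with a stated time of 72 h (a higher number here means a weaker inhibitor, a lower number a stronger inhibitor), compound 2 gives 2700 nM. Compound 1 `COc1cccc(N2C(=O)CS/C2=N\c2csc(-c3ccc(C)cc3)c2)c1` reaches only a limit of the assay; in this assay compound 1 gives > 50000 nM, a limit and not a number. The change from compound 1 to compound 2 is methoxy in place of methyl on an aromatic carbon, and it brought an at least 18-fold lower number from compound 1 to compound 2 (1.26 log units; beyond the scatter), resting on (the limit of > 50000 nM in this assay, at which 1 of the 2 values shown sits).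

Compound 3 `COc1cccc(N2C(=O)CS/C2=N\c2csc(-c3ccc(Cl)cc3)c2)c1` differs from compound 2 by chloro in place of methoxy on an aromatic carbon; the same difference, cut one bond further out, reads 4-methoxyphenyl to 4-chlorophenyl. For the measured compounds named here, the only measured step that bears on this change is the one from compound 1 to compound 2, where the methoxy group was present in the compound with the lower number. Taking that group away is therefore expected to raise the number in this assay. For compound 3 a step of a 3.7-fold higher number from compound 2 to compound 3 (0.57 log units; beyond the scatter) is expected. Compound 3 is estimated at 10000 nM, in the range 3000 nM to 50000 nM.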

Compound 3, half-maximal inhibitory concentration: > 50000 nM
Compound 3 ended at the assay's limit; the forecaster's own chance of this, stated with the estimate: 30%; middle value at least 5.0-fold (0.69 log units) away from the limit.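

In this assay, replacing methoxy with chloro on the 4-methoxyphenyl group brought an at least 18-fold higher number from compound 2 to compound 3 (1.26 log units; beyond the scatter), so methyl is not the only replacement here that loses the definite number. Of the three groups shown at this place, only methoxy in compound 2 gives a number, while methyl in compound 1 and chloro in compound 3 both leave the compound at the limit of the assay. The step between compound 1 and compound 3 cannot be read, and the step from compound 2 to compound 3 gives only a minimum size, since both rest on a limit: the limit of > 50000 nM in this assay, at which 2 of the 3 values shown sit.

Going by these compounds, whether a definite number needs methoxy itself stays open, as an amine, a hydroxyl or an ethoxy group at this place could answer that. Also open, on these data alone, is how far compound 1 and compound 3 really lie from each other.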